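This account rests on a few compounds, and the source may have more. Where it says the series, first, only, none or still open, it means among the compounds named here.

Compound 3 `C/C(=C\C(=O)Nc1ccccc1OCCCC(=O)O)c1ccc2c(ccn2C(c2ccccc2)C(C)C)c1` gives 25 nM in an assay on Prostate gland for inhibition of steroid 5-alpha-reductase (Rattus norvegicus) (on this read-out higher numbers stand for weaker inhibition and lower numbers for stronger inhibition), the highest of the three numbers measured, yet its companions sit close: compound 1 `C/C(=C\C(=O)Nc1ccccc1OCCCC(=O)O)c1ccc2c(ccn2C(C(C)C)C(C)C)c1` gives 14 nM and compound 2 `CCC(c1ccccc1)n1ccc2cc(/C(C)=C/C(=O)Nc3ccccc3OCCCC(=O)O)ccc21` gives 19 nM, both within the scatter of compound 3. Compound 4 `C/C(=C\C(=O)Nc1ccccc1OCCCC(=O)O)c1ccc2c(ccn2C(c2ccccc2)c2ccncc2)c1` is the next step, differing from compound 3 by pyridin-4-yl in place of isopropyl on a saturated chain carbon bound to an aromatic carbon and an aromatic nitrogen. Going by the values given here, two measured steps bear on this position. The step of a 1.8-fold higher number from compound 1 to compound 3 (0.25 log units; within the scatter) exchanged isopropyl for phenyl on the same carbon without leaving the scatter, and a 1.4-fold higher number from compound 1 to compound 2 (0.13 log units; within the scatter) rebuilt that carbon's substituents with the same outcome; a 1.3-fold higher number from compound 2 to compound 3 (0.12 log units; within the scatter) was equally quiet. Going by these compounds, nothing measured here involves a pyridin-4-yl group, so the effect of its ring nitrogen is unknown, but every change so far at this carbon has stayed within the scatter. Compound 4 is therefore expected to show a 1.4-fold higher number from compound 3 to compound 4 (0.15 log units; within the scatter), little more than the scatter, with an estimated value of 35 nM in this assay, ranging from 12 nM to 100 nM.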

Compound 4, half-maximal inhibitory concentration: 26 nM
For compound 4 the middle estimate is 1.3-fold (0.13 log units) above the measured one, within the range that was stated.
By their numbers in this assay, from the lowest: compounds 1, 2, 3 and 4 (each within the scatter of the next).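

The first ring nitrogen at this carbon leaves the number in this assay within the scatter: pyridin-4-yl in place of isopropyl gives a 1.0-fold higher number from compound 3 to compound 4 (0.02 log units; within the scatter), and pyridin-4-yl in place of ethyl gives a 1.4-fold higher number from compound 2 to compound 4 (0.14 log units; within the scatter). The change adds a six-membered aromatic ring with a hetero atom and a hydrogen-bond acceptor, neither of which the earlier substituents at this carbon carried, and all four compounds still lie within the scatter of the next. Nothing available here accounts for this lack of a measurable difference.

The compounds shown leave open whether a pyridin-3-yl group at this carbon would behave as pyridin-4-yl does. They also leave open whether a primary amine or a carboxylic acid there would stay within the scatter.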